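Relocating a hydroxyl in a diaryl-substituted analogue

The source may report more compounds than this note shows. Statements on the series, on what has been measured and on what is new or still open speak of the compounds shown alone.

Going by the values given here, compound 2 `Oc1cccc(-c2cc(-c3cccc(C(F)(F)F)c3)cc(-c3ccccc3O)n2)c1` gives 6340 nM in a functional assay on T47D cells (Homo sapiens) for inhibition (on this read-out lower numbers stand for stronger inhibition and higher numbers for weaker inhibition), and holds the only number among the two values recorded. Compound 1 `Oc1cccc(-c2cc(-c3cccc(F)c3)cc(-c3ccccc3O)n2)c1` returns in this assay only a limit, > 50000 nM. Among the compounds with values here, the single measured step, an at least 7.8-fold lower number from compound 1 to compound 2 (0.89 log units; beyond the scatter), concerns the trifluoromethyl group and not the hydroxyl position. Compound 3 `Oc1ccc(-c2cc(-c3cccc(C(F)(F)F)c3)cc(-c3cccc(O)c3)n2)cc1` differs from compound 2 by 4-hydroxyphenyl in place of 2-hydroxyphenyl on an aromatic carbon. Within the data shown here, no measured step bears on this change, so no shift beyond the scatter is expected in either direction, though the uncertainty is wide. Compound 3 is therefore estimated at 8000 nM, between 2000 nM and 40000 nM. The expected step from compound 2 is a 1.3-fold higher number from compound 2 to compound 3 (0.10 log units; within the scatter).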

Compound 3, half-maximal inhibitory concentration: 2630 nM
The estimate for compound 3 lay 3.0-fold (0.48 log units) above the measured number; measured number inside the range.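

Moving the hydroxyl around this ring, with the atoms unchanged, gives a 2.4-fold lower number from compound 2 to compound 3 (0.38 log units; beyond the scatter) in this assay. The position next to the ring nitrogen therefore responds to where the hydroxyl sits, which the earlier step, confined to the trifluoromethyl and fluoro groups on another ring, could not show. Nothing available here accounts for this shift. As far as these compounds go, what stays open is whether an amine or a methoxy group in place of this hydroxyl would give a similar number, and whether the step would hold with fluoro in place of trifluoromethyl.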